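Aromatic chloro at a new place: compound 4 against compound 1

The source may report more compounds than this note shows. Statements on the series, on what has been measured and on what is new or still open speak of the compounds shown alone.

Measured so far in a functional assay on A549 cells (Homo sapiens) for inhibition, read by sulforhodamine B assay, with a stated time of 48 h; a lower number here means a stronger inhibitor of growth, a higher number a weaker inhibitor of growth:
compound 1 `COC(=O)[C@@]1(C)CCC=C2[C@@H]1CC[C@@H](C)[C@]2(C)Cc1c[nH]c2ccccc12`, 5000 nM
compound 2 `COC(=O)[C@@]1(C)CCC=C2[C@@H]1CC[C@@H](C)[C@]2(C)Cc1c[nH]c2ccc(Cl)cc12`, 16000 nM
compound 3 `COC(=O)[C@@]1(C)CCC=C2[C@@H]1CC[C@@H](C)[C@]2(C)Cc1c[nH]c2ccc(OC)cc12`, 2200 nM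

Compound 1 stands second highest of these three numbers; nearest is compound 3 (a 2.3-fold lower number from compound 1 to compound 3 (0.36 log units; beyond the scatter)), furthest compound 2 (a 3.2-fold higher number from compound 1 to compound 2 (0.51 log units; beyond the scatter)). Compound 4 `COC(=O)[C@@]1(C)CCC=C2[C@@H]1CC[C@@H](C)[C@]2(C)Cc1c[nH]c2c(Cl)cccc12` differs from compound 1 by chloro in place of hydrogen on an aromatic carbon. Going by the values given here, the one measured step with the same entering group is the chloro step from compound 1 to compound 2, at another place on the same ring, a modest rise; the methoxy steps do not bear on a chloro. A modest rise in this assay is therefore expected, the different place making the parallel loose. Compound 4 is estimated at 10000 nM, range 3000 nM to 30000 nM, an expected step of a 2.0-fold higher number from compound 1 to compound 4 (0.30 log units; within the scatter).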

Compound 4, concentration for 50% growth inhibition: 22000 nM
Compound 4: the middle estimate sits 2.2-fold (0.34 log units) below what was measured; the range from low to high includes it.
By their numbers in this assay, from the lowest: compound 3; then compound 1; then compounds 2 and 4 (each within the scatter of the next).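

In this assay chloro in place of hydrogen at this carbon, ortho to a fused ring, also raises the number (a 4.4-fold higher number from compound 1 to compound 4 (0.64 log units; beyond the scatter)), so the rise is not confined to the chloro place in compound 2. Compound 3, with methoxy, goes against any reading that substitution on this ring raises the number in general. Nothing measured here accounts for the chloro steps. Open, from the compounds shown here alone, is whether methoxy at the chloro carbon of compound 4 would lower the number, and how an amine or a carboxylic acid there would behave.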